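The source may report more compounds than this note shows. Statements on the series, on what has been measured and on what is new or still open speak of the compounds shown alone.

Measured in a functional assay on OCI-Ly7 cells (Homo sapiens) for antiproliferative activity, read by WST assay, with a stated time of 3 days; a lower number here means a stronger inhibitor, a higher number a weaker inhibitor:
Compound 1 `N#Cc1cc(=O)[nH]c(=O)n1[C@@H]1O[C@H](CO)[C@@H](O)[C@H]1O` gives > 50000 nM, a limit.
Compound 2 `CN(C)c1cc(=O)[nH]c(=O)n1[C@@H]1O[C@H](CO)[C@@H](O)[C@H]1O` gives > 50000 nM, a limit.
Compound 3 `O=Cc1cc(=O)[nH]c(=O)n1[C@@H]1O[C@H](CO)[C@@H](O)[C@H]1O` gives > 50000 nM, a limit.

Compound 3 therefore has no number of its own, and it has no readable rank among the three. Every result so far sits at the same boundary: the limit of > 50000 nM in this assay, at which 3 of the 3 values shown sit.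

Compound 4 `O=Cc1c(F)c(=O)[nH]c(=O)n1[C@@H]1O[C@H](CO)[C@@H](O)[C@H]1O` carries one change to compound 3, with fluoro in place of hydrogen on an aromatic carbon, ortho to a formyl group (fluoro in place of hydrogen on an aromatic carbon).

The measured steps offer little guidance. They are a step that the two limits leave unreadable from compound 1 to compound 2, a step that the two limits leave unreadable from compound 1 to compound 3 and a step that the two limits leave unreadable from compound 2 to compound 3. All three exchange groups on an aromatic carbon, none introduces fluoro, and none has a size that can be read. The data therefore give no measured size for this change.

The expectation starts from compound 3 at > 50000 nM, which is a limit. Compound 4 is expected to remain weak in this assay, quite possibly at the same limit, and any readable number is expected to lie on the stronger side. The estimated change is an at least 1.2-fold lower number from compound 3 to compound 4 (0.09 log units; that floor lies within the scatter), and this estimate is loose. For compound 4 the expected value is 40000 nM, with an estimated range from 5000 nM to 100000 nM.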

Compound 4, half-maximal inhibitory concentration: 600 nM
For compound 4 the middle estimate is 67-fold (1.82 log units) above the measured one; the whole stated range lies above it.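

In this assay, within the data shown here, placing fluoro in place of hydrogen on the aromatic carbon ortho to a formyl group gives an at least 83-fold lower number from compound 3 to compound 4 (1.92 log units; beyond the scatter), the first step in this set whose size can be read, and the true size may be larger still, as compound 3 supplies only a limit. Compounds 1, 2 and 3 all carry hydrogen at this position and differ only in the group at another aromatic carbon, and the steps among them cannot be read, so they gave no sign that this position could matter for the read-out. Exchanging this single hydrogen takes the series off a shared boundary, and compound 4 is the only compound shown with a number rather than a limit, the others remaining at that boundary: the limit of > 50000 nM in this assay, at which 3 of the 4 values shown sit.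

The compounds shown leave open whether fluoro would have a similar effect with nitrile or dimethylamino in place of the formyl group, as the only pair that tests it carries formyl. They also leave open how chloro, methyl or an amine at the same position would compare with fluoro, and whether the formyl group itself can be exchanged once fluoro is present.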